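Tosyl ester of the phenol in the methoxyphenyl triazole series

The source may report more compounds than this note shows. Statements on the series, on what has been measured and on what is new or still open speak of the compounds shown alone.

Measured so far:
compound 1 `C=C1C(=O)[C@]23C[C@@]1(O)CC[C@H]2c1ccc(OS(=O)(=O)c2ccc(C)cc2)c(C)c1[C@@H]3Cn1cc(-c2ccc(F)cc2)nn1`: 1630 nM
compound 2 `C=C1C(=O)[C@]23C[C@@]1(O)CC[C@H]2c1ccc(O)c(C)c1[C@@H]3Cn1cc(-c2ccc(OC)cc2)nn1`: 220 nM

Going by the values given here, in a functional assay on SW480 cells (Homo sapiens) for cytotoxicity, read by MTT assay, with a stated time of 4 days (on this read-out higher numbers stand for weaker inhibition and lower numbers for stronger inhibition), compound 2 gives the lower of the two numbers; compound 1 stands higher, beyond the usual scatter, though the two differ in two places, so no single-change step is available. Compound 3 `C=C1C(=O)[C@]23C[C@@]1(O)CC[C@H]2c1ccc(OS(=O)(=O)c2ccc(C)cc2)c(C)c1[C@@H]3Cn1cc(-c2ccc(OC)cc2)nn1` carries (4-methylphenyl)sulfonyl in place of hydrogen on an oxygen on an aromatic ring. Direction can only be guessed from the weaker result of compound 1, 1630 nM, which also carries the tosyl ester. Compound 3 is therefore estimated at 900 nM, within 300 nM to 2700 nM. The expected step of a 4.1-fold higher number from compound 2 to compound 3 (0.61 log units; beyond the scatter) would be a weakening beyond the scatter.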

Compound 3, half-maximal inhibitory concentration: 1640 nM
Compound 3: the middle estimate sits 1.8-fold (0.26 log units) below what was measured; low and high end bracket the measured number.
By their numbers in this assay, from the lowest: compound 2; then compounds 1 and 3 (each within the scatter of the next).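

In this assay, going by these compounds alone, (4-methylphenyl)sulfonyl in place of hydrogen on an oxygen on an aromatic ring gives a 7.5-fold higher number from compound 2 to compound 3 (0.87 log units; beyond the scatter) and so provides the first single-change reading at this position, a weakening beyond the scatter. With that sulfonyl ester in place, methoxy in place of fluoro on an aromatic carbon gives a 1.0-fold higher number from compound 1 to compound 3 (0.00 log units; within the scatter) and does not separate the two groups. No measured property bears on the reason for either step.

On these data alone, whether fluoro and methoxy also read alike with the free hydroxy remains open. So does the effect of a smaller group on that oxygen, such as methyl or acetyl.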